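Sulfonamide series: pyrazole to isoxazole swap, cytotoxicity notes

The compounds below may be only part of what the source reports. "The series", "measured", "known", "first", "only" and "open" are said of these compounds alone.

Measured so far in a functional assay on MT4 cells (Homo sapiens) for cytotoxicity, read by CellTiter-Glo, with a stated time of 5 days; on this read-out lower numbers stand for an effect already at smaller amounts and higher numbers for an effect only at larger amounts of compound:
- compound 1, `Cc1ccc(-c2c(C)n[nH]c2C)cc1S(=O)(=O)NC1CCCC1`, gives 5420 nM
- compound 2, `Cc1noc(C)c1-c1cc(-c2c(C)noc2C)c2nc(C3CC3)[nH]c2c1`, gives 80 nM
- compound 3, `Cc1noc(C)c1-c1cc(S(=O)(=O)NC2CCCC2)c2cc(N3CCCC3)c(=O)[nH]c2c1`, gives 140 nM

Compound 1 stands at the highest number of the three, so its effect on the cells appears only at the largest amount; the gaps to compound 3 and to compound 2 are both beyond the scatter. Compounds 2 and 3 share neither the core of compound 1 nor the change of interest, so they serve only as reference points for the range seen in this assay.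

The step from compound 1 to compound 4, `Cc1ccc(-c2cnoc2)cc1S(=O)(=O)NC1CCCC1`, is a single replacement on the aromatic ring that carries the methyl group: 1,2-oxazol-4-yl in place of 3,5-dimethyl-1H-pyrazol-4-yl on an aromatic carbon. The group that enters is the smaller of the two, with no hydrogen-bond donor and one more acceptor. Among the measured compounds shown here, no measured pair in this set isolates this change, so there is no direct precedent for its size or direction in this assay.

With only compound 1 as the anchor, the working expectation is a step of a 1.1-fold higher number from compound 1 to compound 4 (0.04 log units; within the scatter), that is, none beyond the scatter. Compound 4 is therefore estimated at 6000 nM, with a range from 2500 nM to 15000 nM.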

Compound 4, half-maximal effective concentration: 43200 nM
Estimate against measurement, compound 4: 7.2-fold (0.86 log units) below; the whole stated range lies below it.
By their numbers in this assay, from the lowest: compounds 2 and 3 (each within the scatter of the next); then compound 1; then compound 4.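

In this assay, this aromatic carbon, para to the methyl group, proves sensitive to the choice of five-membered ring: 1,2-oxazol-4-yl in place of 3,5-dimethyl-1H-pyrazol-4-yl gives an 8.0-fold higher number from compound 1 to compound 4 (0.90 log units; beyond the scatter) on an otherwise unchanged structure. The earlier compounds shown here gave only a range of values, whereas this pair ties a step beyond the scatter to a single place, with the cytotoxic effect appearing only at a larger amount of compound. The replacement changes several things at once, namely the methyl groups, the ring hetero atoms and the hydrogen-bond donor, and no available evidence assigns the step to any one of them or explains it.

The compounds shown leave open which of these differences carries the step, and an unsubstituted 1H-pyrazol-4-yl at the same aromatic carbon would separate the methyl groups from the change of ring hetero atoms. Also open, from the compounds shown here alone, is whether the same step would appear with a different group in place of the cyclopentyl on the sulfonamide nitrogen, such as a longer alkyl chain or a chain ending in an amine.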